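The source may report more compounds than this note shows. Statements on the series, on what has been measured and on what is new or still open speak of the compounds shown alone.

Compound 1, `O=C(Nc1cccc(-n2cc(-c3ccncc3)c(-c3ccc(Cl)c(O)c3)n2)c1)Nc1cccc(C(F)(F)F)c1`. In a functional assay on NCI-H322M cells (Homo sapiens) for inhibition, read by sulforhodamine B assay, with a stated time of 48 h (a higher number here means a weaker inhibitor of growth, a lower number a stronger inhibitor of growth), compound 1 gives > 32500 nM, which is a limit of the assay rather than a number.
Compound 2, `COc1cc(-c2nn(-c3cccc(NC(=O)Nc4cc(C(F)(F)F)cc(C(F)(F)F)c4)c3)cc2-c2ccncc2)ccc1Cl`. In this assay compound 2 gives 3000 nM.
Compound 3, `COc1cc(-c2nn(-c3cccc(NC(=O)Nc4cccc(C(F)(F)F)c4)c3)cc2-c2ccncc2)ccc1Cl`. In this assay compound 3 gives 4730 nM.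

Compound 2 holds the lowest of the two actual numbers. Going by the values given here, the only other number lies a 1.6-fold higher number from compound 2 to compound 3 (0.20 log units; within the scatter), within the scatter, so the two cannot be ordered against each other. The third value is only (the limit of > 32500 nM in this assay, at which 1 of the 3 values shown sits).

Compound 4, `O=C(Nc1cccc(-n2cc(-c3ccncc3)c(-c3ccc(Cl)c(O)c3)n2)c1)Nc1cc(C(F)(F)F)cc(C(F)(F)F)c1`, has not been measured. It differs from compound 2 in one place: hydrogen in place of methyl on an oxygen on an aromatic ring. Cut one bond further out, this reads methoxy to hydroxy, or 4-chloro-3-methoxyphenyl to 4-chloro-3-hydroxyphenyl.

Among the compounds with values here, one measured step bears on this change, run in the opposite direction: an at least 6.8-fold lower number from compound 1 to compound 3 (0.83 log units; beyond the scatter). Undoing that same change here should move the number the other way, upward by at least a modest amount, and it may well land at the limit again. Compound 4 is therefore expected to give about 25000 nM in this assay, within a range of 8000 nM to 80000 nM. That estimate corresponds to an expected 8.3-fold higher number from compound 2 to compound 4 (0.92 log units; beyond the scatter).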

Compound 4, concentration for total growth inhibition: 5390 nM
Compound 4: middle estimate off by 4.6-fold (0.67 log units), on the high side; measured number below the stated range.
By their numbers in this assay, from the lowest: compounds 2, 3 and 4 (each within the scatter of the next). At a limit, above all of these: compound 1.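

In this assay, changing methoxy to hydroxy gives no readable change when the second trifluoromethyl group is present: a 1.8-fold higher number from compound 2 to compound 4 (0.25 log units; within the scatter). The large difference between compound 3 and compound 1 therefore does not carry over to this pair, and the size of the methoxy-to-hydroxy step depends on the rest of the molecule: the same change on two cores in this assay, an at least 6.8-fold lower number (0.83 log units; beyond the scatter) from compound 1 to compound 3 and a 1.8-fold lower number (0.25 log units; within the scatter) from compound 4 to compound 2, at least 3.8-fold (0.58 log units) apart, beyond the scatter of two such steps Read the other way, adding trifluoromethyl to the hydroxy compounds gives an at least 6.0-fold lower number from compound 1 to compound 4 (0.78 log units; beyond the scatter), a step that rests on a limit of the assay for compound 1, while the same addition to the methoxy compounds stays within the scatter: the same change on two cores in this assay, a 1.6-fold higher number (0.20 log units; within the scatter) from compound 2 to compound 3 and an at least 6.0-fold higher number (0.78 log units; beyond the scatter) from compound 4 to compound 1, at least 3.8-fold (0.58 log units) apart, beyond the scatter of two such steps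

The compounds shown leave open whether a longer chain on that oxygen, such as ethoxy, or an amine in place of the methoxy would behave like methoxy or like hydroxy. They also leave open whether a nitrile in place of the second trifluoromethyl group would have the same effect.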